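Working notes: from compound 3 to compound 4

A few compounds are considered here, and "the series" means these few. Any claim that something is new, unique, unknown or untested is made for them only; others in the source may bear on it.

Measured compounds, all in an ADME assay on Vero cells (Chlorocebus sabaeus) for cytotoxicity, read by MTT assay, with a stated time of 72 h (a higher number here means a weaker inhibitor, a lower number a stronger inhibitor), as read-out:
- compound 1 `Cc1ccc(C)n1-c1ccc(C(=O)N/N=C/c2ccc(N(C)C)cc2)cc1` gives "not determined" (no result reported)
- compound 2 `O=C(NNC(=O)c1ccccc1[N+](=O)[O-])c1ccc(-n2cccc2)cc1` gives 182000 nM
- compound 3 `CC(=O)N1N=C(c2ccc(-n3c(C)ccc3C)cc2)OC1c1cccc([N+](=O)[O-])c1` gives 188000 nM

Among the measured compounds shown here, only two of the three compounds carry a number, since compound 1 has no reported result. Compound 3 stands at 188000 nM and compound 2 at 182000 nM in this assay, so the two lie within the scatter of each other and neither can be placed ahead.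

The next compound to be measured is compound 4 `CC(=O)N1N=C(c2ccc(-n3c(C)ccc3C)cc2)OC1c1c(Cl)cccc1Cl`, which keeps the core of compound 3. It has 2,6-dichlorophenyl in place of 3-nitrophenyl on a saturated ring carbon and the acetyl group stays as it is.

For the measured compounds named here, no pair of measured compounds differs in one place, so the data give no direct size for this change. Going by the values given here, the only guide is that compound 2 at 182000 nM and compound 3 at 188000 nM sit together. No step beyond the scatter is expected, with a slight lean towards a lower number. The expected step is a 1.3-fold lower number from compound 3 to compound 4 (0.10 log units; within the scatter) and stays a rough expectation. The estimate for compound 4 is 150000 nM, with an expected range from 60000 nM to 320000 nM as a working figure.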

Compound 4, half-maximal inhibitory concentration: 221000 nM
Compound 4: the middle estimate sits 1.5-fold (0.17 log units) below what was measured; the range from low to high includes it.
By their numbers in this assay, from the lowest: compounds 2, 3 and 4 (each within the scatter of the next).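

In this assay, among the compounds shown here, 2,6-dichlorophenyl in place of 3-nitrophenyl on the saturated ring carbon gives a 1.2-fold higher number from compound 3 to compound 4 (0.07 log units; within the scatter), the first single-place step, and it does not separate the two compounds. At this position, then, exchanging one substituted phenyl ring for the other, with the hydrogen-bond acceptors of the leaving group absent from the entering group, leaves the read-out within the scatter. Nothing measured on these compounds speaks to the reason for this result.

What the compounds leave open is whether any group on this saturated ring carbon can move the number beyond the scatter, for instance a phenyl ring carrying an amine or a carboxylic acid, or a longer alkyl chain in place of the ring. The acetyl group on the neighbouring ring atom also stays the same in compound 3 and compound 4, so the effect of replacing it with a hydrogen or a propionyl group cannot be read from this step.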